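The compounds below may be only part of what the source reports. "The series", "measured", "known", "first", "only" and "open" are said of these compounds alone.

Three compounds built on a shared core have been run in an ADME assay on L02 cells (Homo sapiens) for cytotoxicity, read by MTT assay, with a stated time of 24 h; on this read-out higher numbers stand for weaker inhibition and lower numbers for stronger inhibition. Compound 1 `CN1C/C(=C\c2cccnc2)C(=O)/C(=C/c2ccccc2F)C1` gives 15900 nM in this assay. Compound 3 `CN1C/C(=C\c2ccncc2)C(=O)/C(=C/c2ccccc2F)C1` differs from compound 1 by pyridin-4-yl in place of pyridin-3-yl on a double-bonded chain carbon bound to a double-bonded ring carbon, and in this assay compound 3 gives 14900 nM; the step is a 1.1-fold lower number from compound 1 to compound 3 (0.03 log units; within the scatter). Compound 2 `CN1C/C(=C\c2ccc(C(F)(F)F)cc2)C(=O)/C(=C/c2cccnc2)C1` carries a different core, and the difference between the two cores is not broken down here. In this assay compound 2 gives 15600 nM. The three numbers sit within the usual scatter of one another, so nothing separates compound 1, compound 2 and compound 3 on this read-out.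

Compound 4 `CN1C/C(=C\c2ccncc2)C(=O)/C(=C/c2ccc(C(F)(F)F)cc2)C1` has not yet been measured in this assay. Compound 4 differs from compound 2 by pyridin-4-yl in place of pyridin-3-yl on a double-bonded chain carbon bound to a double-bonded ring carbon. Among the measured compounds shown here, this is the same change as the one from compound 1 to compound 3, made at the same place, and it occurs twice among the four compounds. Because that earlier step was a 1.1-fold lower number from compound 1 to compound 3 (0.03 log units; within the scatter), the step from compound 2 to compound 4 is expected to be a 1.0-fold lower number from compound 2 to compound 4 (0.00 log units; within the scatter), that is, a change that stays within the scatter. On that basis compound 4 is estimated at 15500 nM in this assay. For the measured compounds named here, the estimate for compound 4 is expected to fall between 8000 nM and 30000 nM, with the wider band reflecting that only one earlier step of this kind supports it.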

Compound 4, half-maximal inhibitory concentration: 17400 nM
Beside the measured number, compound 4's estimate is 1.1-fold (0.05 log units) below it, within the range that was stated.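

In this assay, pyridin-4-yl in place of pyridin-3-yl on a double-bonded chain carbon bound to a double-bonded ring carbon gives a 1.1-fold higher number from compound 2 to compound 4 (0.05 log units; within the scatter). Set against the earlier step on the core of compound 1, the new step does not differ from it: the same change on two cores in this assay, a 1.1-fold lower number (0.03 log units; within the scatter) from compound 1 to compound 3 and a 1.1-fold higher number (0.05 log units; within the scatter) from compound 2 to compound 4, 1.2-fold (0.08 log units) apart, within the scatter of two such steps. In these two pairs the change therefore carries from one core to the other with no readable effect on either core, but each step lies within the scatter, so the agreement is between two steps too small to read a direction from, and it does not show that the change would behave the same way on any further core or on any other read-out.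

The compounds shown leave open whether any replacement at this place can move the number beyond the scatter, since only pyridin-3-yl and pyridin-4-yl appear there. A group of another kind on the same double-bonded chain carbon, such as a phenyl ring bearing a carboxylic acid or an amine, would test whether this place matters at all for this read-out.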